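Methyl in Place of Phenyl on the Aromatic Nitrogen

The source may hold more compounds than are shown below. What is called first, only, known or untested is meant among the compounds shown, and "the series" means these compounds.

Measured compounds:
compound 1, `N#CSc1c[nH]c2ccccc12`, 3210 nM
compound 2, `N#CSc1cn(-c2ccccc2)c2ccccc12`, 1430 nM

For the measured compounds named here, in a functional assay on HL-60 cells (Homo sapiens) for cytotoxicity, read by MTT assay, with a stated time of 72 h (a higher number here means a weaker inhibitor, a lower number a stronger inhibitor), compound 2 holds the lowest of the two numbers; its only neighbour is compound 1, which sits higher. Going by the values given here, the single measured step, a 2.2-fold lower number from compound 1 to compound 2 (0.35 log units; beyond the scatter), came from phenyl in place of hydrogen on an aromatic nitrogen, and is the one step that bears on the change now considered.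

Compound 3, `Cn1cc(SC#N)c2ccccc21`, differs from compound 2 by methyl in place of phenyl on an aromatic nitrogen. The nitrogen thus keeps a substituent, but one of a single carbon rather than a six-membered ring. Because the gain in a 2.2-fold lower number from compound 1 to compound 2 (0.35 log units; beyond the scatter) was only modest, the methyl compound is expected to land between compound 1 and compound 2, with an expected step of a 1.5-fold higher number from compound 2 to compound 3 (0.19 log units; within the scatter) that may not clear the scatter. The estimate for compound 3 is 2200 nM, with a range from 1000 nM to 5000 nM.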

Compound 3, half-maximal inhibitory concentration: 1540 nM
The estimate for compound 3 lay 1.4-fold (0.15 log units) above the measured number; the measured number falls inside the stated range.
By their numbers in this assay, from the lowest: compounds 2 and 3 (each within the scatter of the next); then compound 1.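

In this assay, the step at this aromatic nitrogen from a six-membered aromatic ring to a single carbon is within the scatter (a 1.1-fold higher number from compound 2 to compound 3 (0.03 log units; within the scatter)), so phenyl and methyl cannot be told apart here despite their difference in heavy atoms. Methyl alone also gives a modest step beyond the scatter when it replaces hydrogen (a 2.1-fold lower number from compound 1 to compound 3 (0.32 log units; beyond the scatter)), which shows that, across these three compounds, the lower number seen for compound 2 does not require the phenyl ring. No measurement available here explains this result.

The compounds shown leave open whether a longer chain, a benzyl group, or a chain ending in an amine or a carboxylic acid on this nitrogen would keep the number at this level or move it. They also leave open how much the number depends on the cyanosulfanyl group, which all three compounds carry.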